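The source may report more compounds than this note shows. Statements on the series, on what has been measured and on what is new or still open speak of the compounds shown alone.

Compound 1 `CC(C)n1cnc2c(NC(=N)N)nc(NCCO)nc21`: 12400 nM
Compound 2 `CC(C)[C@H](CO)Nc1nc(NC(=N)N)c2ncn(C(C)C)c2n1`: 10500 nM
Compound 3 `CC(C)[C@H](N)COc1nc(NC(=N)N)c2ncn(C(C)C)c2n1`: 3400 nM

In a functional assay on MCF7 cells (Homo sapiens) for inhibition, read by fluorescence, with a stated time of 72 h (on this read-out lower numbers stand for stronger inhibition and higher numbers for weaker inhibition), compound 3 has the lowest number of the three, at 3400 nM. Compound 4 `CC(C)n1cnc2c(NC(=N)N)nc(NC3CC3)nc21` carries cyclopropylamino in place of 2-amino-3-methylbutoxy on an aromatic carbon. Two measured steps brought in that departing group, a 3.6-fold lower number from compound 1 to compound 3 (0.56 log units; beyond the scatter) and a 3.1-fold lower number from compound 2 to compound 3 (0.49 log units; beyond the scatter), and both were modest. A change within the amino-linked chains, a 1.2-fold lower number from compound 1 to compound 2 (0.07 log units; within the scatter), stayed within the scatter. Going by the values given here, no compound with cyclopropylamino has been measured yet, but removing 2-amino-3-methylbutoxy is expected to reverse a step of similar size, towards a higher number. The expected change is a 2.9-fold higher number from compound 3 to compound 4 (0.47 log units; beyond the scatter). For compound 4 the estimated value is 10000 nM, with an expected range of 4000 nM to 25000 nM.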

Compound 4, half-maximal inhibitory concentration: 5400 nM
Compound 4: the middle estimate sits 1.9-fold (0.27 log units) above what was measured; the range from low to high includes it.
By their numbers in this assay, from the lowest: compounds 3, 4, 2 and 1 (each within the scatter of the next, the first and the last beyond it).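

Replacing 2-amino-3-methylbutoxy with cyclopropylamino on the aromatic carbon between two ring nitrogen atoms gives a 1.6-fold higher number from compound 3 to compound 4 (0.20 log units; within the scatter), so a number in this range does not depend on that chain, its oxygen or its stereocentre. Among the amino-linked groups, cyclopropyl gives a 1.9-fold lower number from compound 2 to compound 4 (0.29 log units; within the scatter) and a 2.3-fold lower number from compound 1 to compound 4 (0.36 log units; beyond the scatter), so only the step from the 2-hydroxyethyl compound clears the scatter. Nothing available explains these steps. From the compounds shown here alone, it remains open whether cyclobutylamino, cyclohexylamino or a plain amino group at this position would shift the number.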